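A few compounds are considered here, and "the series" means these few. Any claim that something is new, unique, unknown or untested is made for them only; others in the source may bear on it.

Working notes on the series. For the measured compounds named here, the two compounds measured so far in a functional assay on cells (Cancer cell lines, Homo sapiens) for cytotoxicity, with a stated time of 48 h (a lower number here means a stronger inhibitor of growth, a higher number a weaker inhibitor of growth), are compound 1 `COc1cc2c(/C=C3/C(=O)Nc4ccc(O)cc43)c(Cl)n(Cc3cc(OC)c(OC)c(OC)c3)c2cc1C` and compound 2 `O=C1/C(=C/c2c(Cl)[nH]c3ccccc23)c2ccccc2N1Cc1ccccc1`. In this assay compound 1 gives 1410 nM, and in this assay compound 2 gives 4170 nM. Compound 1 thus stands at the lowest of the two numbers; its nearest neighbour is compound 2, whose number is higher by a margin beyond the scatter. Compound 2 differs from compound 1 in more than one place, so the gap between the two numbers cannot be assigned to any single change.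

The next compound is compound 3 `COc1cc2c(/C=C3/C(=O)Nc4cccc(Cl)c43)c(Cl)n(Cc3cc(OC)c(OC)c(OC)c3)c2cc1C`. It keeps the core of compound 1 and differs from it by a group of 12 heavy atoms (9 carbon, 1 nitrogen, 1 oxygen, 1 chlorine; one five-membered non-aromatic ring with 1 hetero atom, one six-membered aromatic ring of carbon only) in place of a group of 12 heavy atoms (9 carbon, 1 nitrogen, 2 oxygen; one five-membered non-aromatic ring with 1 hetero atom, one six-membered aromatic ring of carbon only), on an aromatic carbon. Going by the values given here, no pair of measured compounds shows a change of this kind, so no step for it can be read from the data. In this assay a step of modest size is expected, with the direction open; a step beyond the scatter is not expected with any confidence. For compound 3 the estimate in this assay is 2000 nM, within a range of 600 nM to 6000 nM, which corresponds to an expected step of a 1.4-fold higher number from compound 1 to compound 3 (0.15 log units; within the scatter).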

Compound 3, concentration for 50% growth inhibition: 2950 nM
The estimate for compound 3 lay 1.5-fold (0.17 log units) below the measured number, within the range that was stated.
By their numbers in this assay, from the lowest: compound 1; then compounds 3 and 2 (each within the scatter of the next).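

In this assay, for the compounds shown here, the swap on this aromatic carbon, two ring bonds from the ring nitrogen, gives the first readable step: a 2.1-fold higher number from compound 1 to compound 3 (0.32 log units; beyond the scatter), a modest step but one beyond the scatter. The two groups match in their 12 heavy atoms and their rings, and the entering group differs in having 1 chlorine in place of an oxygen, with 1 hydrogen-bond donor and 1 hydrogen-bond acceptor against 2 hydrogen-bond donors and 2 hydrogen-bond acceptors, so the gap can be assigned to this one place, unlike the gap between compound 1 and compound 2. No measurement of any property of these compounds is available to account for the step.

This single pair changes the oxygen and the chlorine together, so the compounds shown do not separate the part played by losing the one from the part played by gaining the other. Going by these compounds, how an amine or a carboxylic acid in this group would stand in this assay also remains open, as does whether the step would keep its size and direction on a different core.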